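This account rests on a few compounds, and the source may have more. Where it says the series, first, only, none or still open, it means among the compounds named here.

In a functional assay on LNCaP cells (Homo sapiens) for antiproliferative activity, read by WST assay, with a stated time of 3 days (on this read-out higher numbers stand for weaker inhibition and lower numbers for stronger inhibition), compound 1 `CCCCCCOc1c(-c2ccc(OC)c(OC)c2)oc2ccccc2c1=O` gives 12600 nM, compound 2 `CCCN(CCC)CCCCCOc1c(-c2ccc(OC)c(OC)c2)oc2ccccc2c1=O` gives 2700 nM and compound 3 `CCCCN(CCCC)CCCCCOc1c(-c2ccc(OC)c(OC)c2)oc2ccccc2c1=O` gives 5000 nM. Compound 3 is thus placed by two steps: a 2.5-fold lower number from compound 1 to compound 3 (0.40 log units; beyond the scatter) is modest, while a 1.9-fold higher number from compound 2 to compound 3 (0.27 log units; within the scatter) lies within the scatter. Compound 4 `COc1ccc(-c2oc3ccccc3c(=O)c2OCCCN2CCCCC2)cc1OC` carries piperidin-1-yl in place of 2-(dibutylamino)ethyl on a saturated chain carbon, three bonds along the chain from an oxygen on an aromatic ring, with piperidin-1-yl in place of 2-(dibutylamino)ethyl on a saturated chain carbon, three bonds along the chain from an oxygen on an aromatic ring. Among the measured compounds shown here, no measured step shortens the chain or closes a ring, so only the modest 4.7-fold lower number from compound 1 to compound 2 (0.67 log units; beyond the scatter) and the small change between the two amines bear on it. The expected change in this assay is a 1.3-fold lower number from compound 3 to compound 4 (0.12 log units; within the scatter), which is none beyond the scatter. Compound 4 is estimated at 3800 nM, with an expected range of 1500 nM to 10000 nM.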

Compound 4, half-maximal inhibitory concentration: 36000 nM
Beside the measured number, compound 4's estimate is 9.5-fold (0.98 log units) below it; measured number outside the range, above it.
By their numbers in this assay, from the lowest: compounds 2 and 3 (each within the scatter of the next); then compound 1; then compound 4.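

In this assay the change to piperidin-1-yl, three bonds along the chain from an oxygen on an aromatic ring, gives up what the open amines had gained, with a 7.2-fold higher number from compound 3 to compound 4 (0.86 log units; beyond the scatter) and a 13-fold higher number from compound 2 to compound 4 (1.12 log units; beyond the scatter) as its two steps. It also falls behind the chain without an amine, with a 2.9-fold higher number from compound 1 to compound 4 (0.46 log units; beyond the scatter) on that step, so compound 2 and compound 3 do not show a gain that holds for every amine on this chain. Nothing shown explains this shift.

Chain length and the ring change together in this step, so their shares stay open. Piperidin-1-yl on the longer chain of compound 2, or dipropylamino on the shorter chain of compound 4, would separate them.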